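The compounds below may be only part of what the source reports. "The series", "measured", "known", "first", "only" and "open" are said of these compounds alone.

Values in a functional assay on HT-29 cells (Homo sapiens) for inhibition, read by MTT assay, with a stated time of 72 h; a lower number here means a stronger inhibitor, a higher number a weaker inhibitor:
- Compound 1 `CCCNC(=C\C(=O)/C=C/c1ccc(O)c(OC)c1)/C=C/c1ccc(O)c(OC)c1`: 22700 nM
- Compound 2 `CCC(C)NC(=C\C(=O)/C=C/c1ccc(O)c(OC)c1)/C=C/c1ccc(O)c(OC)c1`: > 25000 nM, a limit of the assay
- Compound 3 `COc1cc(/C=C/C(=O)/C=C(/C=C/c2ccc(O)c(OC)c2)NC2CCCCC2)ccc1O`: not yet measured

Both measured compounds are weak inhibitors in this assay, and the two differ only in the group on the amine nitrogen. Compound 2 has no number of its own, since its > 25000 nM is a limit of the assay. It therefore stands at the limit of > 25000 nM in this assay, at which 1 of the 2 values shown sits.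

Compound 3 carries cyclohexyl in place of sec-butyl on an amine nitrogen, a larger group that now holds a ring. Among the measured compounds shown here, only one measured step bears on this change, as it also alters the group on that nitrogen: an at least 1.1-fold higher number from compound 1 to compound 2 (0.04 log units; that floor lies within the scatter). For the measured compounds named here, that step shows no size beyond the scatter, so no step beyond the scatter is expected here in this assay, though the new ring has no precedent in this small set. Compound 3 may also end as a limit rather than a number.

The estimate for compound 3 is 24000 nM, with an expected range from 10000 nM to 50000 nM. The estimated change is an at least 1.0-fold lower number from compound 2 to compound 3 (0.01 log units; that floor lies within the scatter).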

Compound 3, half-maximal inhibitory concentration: > 25000 nM
Compound 3: only a limit was reported; the forecaster's own chance of this, stated with the estimate: 50%; middle value at least 1.0-fold (0.01 log units) away from the limit.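

In this assay compound 3 gives > 25000 nM, which is a limit of the assay and not a number, so cyclohexyl on the amine nitrogen ends at the same limit as sec-butyl: the limit of > 25000 nM in this assay, at which 2 of the 3 values shown sit. Among the compounds shown here, the step from compound 2 to compound 3 cannot be read, as both of its ends are limits, and the one readable comparison for the new group is against propyl, an at least 1.1-fold higher number from compound 1 to compound 3 (0.04 log units; that floor lies within the scatter). What the result adds is that a six-membered ring on this nitrogen, and not only a branched chain, leaves the compound without a number in this assay.

On these data alone, how far past the limit compound 2 and compound 3 lie remains open, as does whether any group on this nitrogen can give a clearly stronger inhibitor than the propyl of compound 1. The compounds shown say nothing about how a methyl, a benzyl or a hydroxyethyl group would read at this place on the shared core.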